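Swapping the piperidine substituent for a carbamate

The source may hold more compounds than are shown below. What is called first, only, known or untested is meant among the compounds shown, and "the series" means these compounds.

Compound 3 `O=C(CN1CN(c2ccccc2)C2(CCN(C(=O)c3ccc(C4CCCCC4)cc3)CC2)C1=O)N1CCC(CO)CC1` gives 1100 nM in an assay on HEK293 cells for displacement of a labelled ligand from NPC1-like intracellular cholesterol transporter 1 (Homo sapiens) (on this read-out lower numbers stand for stronger inhibition and higher numbers for weaker inhibition), and stands second highest of three; compound 2 `CCOC(=O)C1CCN(C(=O)CN2CN(c3ccccc3)C3(CCN(C(=O)c4ccc(C5CCCCC5)cc4)CC3)C2=O)CC1` gives 900 nM and compound 1 `CC(C)(C)OC(=O)NC1CCN(C(=O)CN2CN(c3ccccc3)C3(CCN(C(=O)c4ccc(C(C)(C)C)cc4)CC3)C2=O)CC1` gives 8300 nM. Compound 4 `CC(C)(C)OC(=O)NC1CCN(C(=O)CN2CN(c3ccccc3)C3(CCN(C(=O)c4ccc(C5CCCCC5)cc4)CC3)C2=O)CC1` differs from compound 3 by (tert-butoxycarbonyl)amino in place of hydroxymethyl on a saturated ring carbon. For the measured compounds named here, the only single-point step seen at this position, a 1.2-fold higher number from compound 2 to compound 3 (0.09 log units; within the scatter), was small, and compound 1, which carries the same carbamate group but a different aryl substituent, gives a much higher number than compound 2 or compound 3. Compound 4 is therefore expected to lie above compound 3, with a 2.3-fold higher number from compound 3 to compound 4 (0.36 log units; beyond the scatter) as the estimated step. The estimate for compound 4 in this assay is 2500 nM, within 800 nM to 8000 nM.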

Compound 4, half-maximal inhibitory concentration: 4800 nM
Compound 4: the middle estimate sits 1.9-fold (0.28 log units) below what was measured, within the range that was stated.
By their numbers in this assay, from the lowest: compounds 2 and 3 (each within the scatter of the next); then compounds 4 and 1 (each within the scatter of the next).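

In this assay the change at this saturated ring carbon now goes beyond the scatter: (tert-butoxycarbonyl)amino gives a 4.4-fold higher number from compound 3 to compound 4 (0.64 log units; beyond the scatter) in place of hydroxymethyl and a 5.3-fold higher number from compound 2 to compound 4 (0.73 log units; beyond the scatter) in place of ethoxycarbonyl. Cyclohexyl in place of tert-butyl on an aromatic carbon gives a 1.7-fold lower number from compound 1 to compound 4 (0.24 log units; within the scatter) and so does not separate these two carbamates. Nothing available bears on the reason for these steps.

As far as these compounds go, whether a free amine or a carboxylic acid on this ring carbon would stay level with compound 2 and compound 3 remains open.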